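Swapping cyclopropyl for hydroxy on the amide-type nitrogen

The source may report more compounds than this note shows. Statements on the series, on what has been measured and on what is new or still open speak of the compounds shown alone.

Compound 1 `CCNC(=O)/C=C/[C@H]1C[C@@H](O)[C@@H](O)C1` and compound 2 `O=C(/C=C/[C@H]1C[C@@H](O)[C@@H](O)C1)NC1CC1` share one core and differ only by cyclopropyl in place of ethyl on an amide-type nitrogen. In an ADME assay on S2 cells (Drosophila melanogaster) for cytotoxicity, read by MTT assay (on this read-out higher numbers stand for an effect only at larger amounts of compound and lower numbers for an effect already at smaller amounts), compound 1 gives only a limit, > 250000 nM. In this assay compound 2 likewise gives only a limit, > 250000 nM. The step that the two limits leave unreadable from compound 1 to compound 2 therefore stays unreadable, as both values sit at the limit of > 250000 nM in this assay, at which 2 of the 2 values shown sit. Compound 3 `O=C(/C=C/[C@H]1C[C@@H](O)[C@@H](O)C1)NO` differs from compound 2 by hydroxy in place of cyclopropyl on an amide-type nitrogen. For the measured compounds named here, no measured step bears on this change, so nothing beyond the scatter is expected. Compound 3 is expected to show 300000 nM (100000 nM to 1000000 nM). The expected step is a step that the limit leaves unreadable from compound 2 to compound 3.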

Compound 3, half-maximal effective concentration: > 250000 nM
Compound 3 was reported as a limit; the forecaster's own chance of this, stated with the estimate: 80%; the middle value is on the limit's open side.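

Compound 3 also gives only a limit, so no step among compound 1, compound 2 and compound 3 can be read in this assay: the limit of > 250000 nM in this assay, at which 3 of the 3 values shown sit.

The compounds shown leave open whether ethyl, cyclopropyl and hydroxy on the amide-type nitrogen differ at all in this assay.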